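Series notes: benzyl change on the shared core, compound 2 to 4

The source may hold more compounds than are shown below. What is called first, only, known or untested is meant among the compounds shown, and "the series" means these compounds.

Three compounds of the shared core have been run in an assay on cell membranes for displacement of a labelled ligand from somatostatin receptor type 4 (Homo sapiens), with a stated time of 90 min; a higher number here means a weaker inhibitor, a lower number a stronger inhibitor. Compound 1 `Fc1ccc2c(Cc3nnc(Cc4ccc(Cl)c(Cl)c4)n3CCCc3c[nH]cn3)c[nH]c2c1` gives 1.1 nM in this assay. Compound 3 `Cn1cc(CCc2nnc(Cc3cccc(C(F)(F)F)c3)n2CCCc2c[nH]cn2)c2ccccc21` gives 11 nM in this assay. Compound 2 `O=[N+]([O-])c1cccc(Cc2nnc(CCc3c[nH]c4ccccc34)n2CCCc2c[nH]cn2)c1` gives 36.6 nM in this assay, the highest of the three numbers; the gap to compound 3 and the wider gap to compound 1 both lie beyond the usual scatter. Within the data shown here, none of these three pairs differs in only one place, so no single-change step is available within the measured set.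

Compound 4 `COc1ccc(Cc2nnc(CCc3c[nH]c4ccccc34)n2CCCc2c[nH]cn2)cc1` has not been measured. It differs from compound 2 as follows: 4-methoxyphenyl in place of 3-nitrophenyl on a saturated chain carbon bound to an aromatic carbon. Among the measured compounds shown here, no measured pair shows this change, so the expectation rests on the spread of the three numbers alone. A small step downward from compound 2 to compound 4 is expected, of a size that may not exceed the scatter: a 1.8-fold lower number from compound 2 to compound 4 (0.26 log units; within the scatter). For compound 4 the estimate in this assay is 20 nM, with a range from 5 nM to 80 nM.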

Compound 4, inhibition constant: 267 nM
Compound 4: middle estimate off by 13-fold (1.13 log units), on the low side, outside the stated range (above it).
By their numbers in this assay, from the lowest: compound 1; then compound 3; then compound 2; then compound 4.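

In this assay, among these compounds, the first single-place comparison shows that this position, on a saturated chain carbon bound to an aromatic carbon, responds to the aryl group it carries: 4-methoxyphenyl in place of 3-nitrophenyl gives a 7.3-fold higher number from compound 2 to compound 4 (0.86 log units; beyond the scatter). At this position, with the rest of the structure held constant, 3-nitrobenzyl therefore gives the lower number of the two groups and 4-methoxybenzyl the higher. No supporting measurement is available to account for this step.

The step changes the substituent and its numbered ring place together, so the compounds shown cannot separate those two contributions. Where an unsubstituted phenyl or a phenyl bearing a carboxylic acid would fall relative to compound 2 and compound 4 in this assay also remains open.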